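From 3-(trifluoromethyl)phenyl to 4-hydroxyphenyl: what to expect

A few compounds are considered here, and "the series" means these few. Any claim that something is new, unique, unknown or untested is made for them only; others in the source may bear on it.

compound 1 `O=C(Nc1ccc(NCC2CCCC2)cc1Cl)c1cc(Cl)ccc1O`: 21500 nM
compound 2 `O=C(Nc1ccc(NCc2cccc(C(F)(F)F)c2)cc1Cl)c1cc(Cl)ccc1O`: 13300 nM

In an ADME assay on A549 cells (Homo sapiens) for cytotoxicity, read by resazurin assay, with a stated time of 48 h (on this read-out higher numbers stand for lower toxicity in this test and lower numbers for higher toxicity in this test), compound 2 gives 13300 nM, and this value lies within the usual scatter of the value for compound 1. The unmeasured compound 3 `O=C(Nc1ccc(NCc2ccc(O)cc2)cc1Cl)c1cc(Cl)ccc1O` keeps the shared core and changes a single group: 4-hydroxyphenyl in place of 3-(trifluoromethyl)phenyl on a saturated chain carbon bound to a nitrogen on an aromatic ring.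

Within the data shown here, only one measured step bears on this place: a 1.6-fold lower number from compound 1 to compound 2 (0.21 log units; within the scatter). It exchanged one group for a quite different one and still stayed within the scatter. Among the measured compounds shown here, no measured compound here carries a hydroxy group, so this single step is only a weak guide.

No change beyond the scatter is therefore expected, and the estimated step in this assay is a 1.4-fold higher number from compound 2 to compound 3 (0.13 log units; within the scatter). For compound 3 the expected value is 18000 nM, with an estimated range of 7000 nM to 45000 nM.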

Compound 3, half-maximal cytotoxic concentration: 116000 nM
Compound 3: the middle estimate sits 6.4-fold (0.81 log units) below what was measured, outside the stated range (above it).
By their numbers in this assay, from the lowest: compounds 2 and 1 (each within the scatter of the next); then compound 3.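

In this assay this position proves sensitive to what it carries: 4-hydroxyphenyl in place of 3-(trifluoromethyl)phenyl gives an 8.7-fold higher number from compound 2 to compound 3 (0.94 log units; beyond the scatter) and so moves beyond the scatter, which the exchange between the two earlier groups did not do. Against cyclopentyl the same group gives a 5.4-fold higher number from compound 1 to compound 3 (0.73 log units; beyond the scatter) as well, so 4-hydroxyphenyl alone stands apart among these three compounds, on the side of lower toxicity in this test. Nothing offered here accounts for this shift.

Going by these compounds, what stays open is whether the hydroxy group itself matters or whether an aromatic ring without trifluoromethyl would behave the same way, a question that a plain phenyl group would help to settle. Also open, on these data alone, is how an amine or a carboxylic acid in place of the hydroxy group would read in this test.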